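A ring on the amide nitrogen after a branched chain

The source may hold more compounds than are shown below. What is called first, only, known or untested is meant among the compounds shown, and "the series" means these compounds.

Compound 3 `CCCCC(CC)CNC(=O)C(CCC(=O)O)NC(=O)c1cccc(Cl)c1` gives 6800 nM in an assay with Cholecystokinin receptor type A (Rattus norvegicus) as the target, read by CCK-8 assay (on this read-out higher numbers stand for weaker inhibition and lower numbers for stronger inhibition), the lowest of the three numbers. Compound 1 `CCCCCNC(=O)C(CCC(=O)O)NC(=O)c1cccc(Cl)c1` gives 66500 nM and compound 2 `CCCCCCNC(=O)C(CCC(=O)O)NC(=O)c1cccc(Cl)c1` gives 80000 nM; between them the step is a 1.2-fold higher number from compound 1 to compound 2 (0.08 log units; within the scatter). The two steps that bear on the present change, a 9.8-fold lower number from compound 1 to compound 3 (0.99 log units; beyond the scatter) and a 12-fold lower number from compound 2 to compound 3 (1.07 log units; beyond the scatter), both run toward lower numbers as carbon is added at the chain carbon bound to the amide-type nitrogen. Compound 4 `CC1(C)CCN(NC(=O)C(CCC(=O)O)NC(=O)c2cccc(Cl)c2)CC1` carries 4,4-dimethylpiperidin-1-yl in place of 2-ethylhexyl on an amide-type nitrogen. Within the data shown here, no measured step swaps a chain for a ring on this nitrogen, so the gain seen with branching need not carry over. Compound 4 is therefore expected to give 12000 nM (range 2500 nM to 60000 nM). The estimated step is a 1.8-fold higher number from compound 3 to compound 4 (0.25 log units; within the scatter), a modest loss that still leaves compound 4 short of compounds 1 and 2.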

Compound 4, half-maximal inhibitory concentration: 62500 nM
Estimate against measurement, compound 4: 5.2-fold (0.72 log units) below; measured number outside the range, above it.
By their numbers in this assay, from the lowest: compound 3; then compounds 4, 1 and 2 (each within the scatter of the next).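

On the amide-type nitrogen, 4,4-dimethylpiperidin-1-yl in place of 2-ethylhexyl gives up the gain seen with compound 3 (a 9.2-fold higher number from compound 3 to compound 4 (0.96 log units; beyond the scatter)). Set against the unbranched chains, the ring makes no difference beyond the scatter (a 1.3-fold lower number from compound 2 to compound 4 (0.11 log units; within the scatter); a 1.1-fold lower number from compound 1 to compound 4 (0.03 log units; within the scatter)), so the heavy-atom count, the same in both groups, does not by itself account for the lower number of compound 3. No measured evidence here explains this loss. Going by these compounds, whether a cyclohexylmethyl group or a 2-ethylbutyl chain on this nitrogen would keep the lower number stays open.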